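This account rests on a few compounds, and the source may have more. Where it says the series, first, only, none or still open, it means among the compounds named here.

Compound 1 `COc1ccc(-c2ccc3c(c2)C(=O)C(=O)N3)cc1` shows the shared core and in a functional assay on K562 cells (Homo sapiens) for antiproliferative activity, read by MTT assay, with a stated time of 48 h (a lower number here means a stronger inhibitor, a higher number a weaker inhibitor), compound 1 gives 6920 nM. Compound 2 `COc1ccc(-c2ccc3c(c2)C(=O)C(=O)N3c2ccc(OC)cc2)cc1` carries a 4-methoxyphenyl on the amide-type nitrogen in the ring. In this assay compound 2 reaches only a limit of the assay, > 10000 nM, the point described as the limit of > 10000 nM in this assay, at which 1 of the 3 values shown sits. Compound 3 `COc1ccc(-c2ccc3c(c2)C(=O)C(=O)N3Cc2ccc(Cl)c(Cl)c2)cc1` bears a 3,4-dichlorobenzyl at the same place and in this assay compound 3 gives 430 nM. The measured steps are an at least 1.4-fold higher number from compound 1 to compound 2 (0.15 log units; that floor lies within the scatter), a 16-fold lower number from compound 1 to compound 3 (1.21 log units; beyond the scatter) and an at least 23-fold lower number from compound 2 to compound 3 (1.36 log units; beyond the scatter); the benzyl brings the lower numbers. Compound 4 `COc1ccc(-c2ccc3c(c2)C(=O)C(=O)N3Cc2ccc(C#N)cc2)cc1` differs from compound 2 by 4-cyanobenzyl in place of 4-methoxyphenyl on an amide-type nitrogen in a ring. For compound 4 the expected step is an at least 6.6-fold lower number from compound 2 to compound 4 (0.82 log units; beyond the scatter), resting on an at least 23-fold lower number from compound 2 to compound 3 (1.36 log units; beyond the scatter). In this assay compound 4 is estimated at 1500 nM, between 400 nM and 6000 nM.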

Compound 4, half-maximal inhibitory concentration: 380 nM
Compound 4: the middle estimate sits 3.9-fold (0.60 log units) above what was measured; the whole stated range lies above it.
By their numbers in this assay, from the lowest: compounds 4 and 3 (each within the scatter of the next); then compound 1. At a limit, above all of these: compound 2.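

In this assay the lower numbers on the amide-type nitrogen in the ring are not confined to 3,4-dichlorobenzyl: 4-cyanobenzyl in place of hydrogen also brings a large step (an 18-fold lower number from compound 1 to compound 4 (1.26 log units; beyond the scatter)), and so it does in place of 4-methoxyphenyl (an at least 26-fold lower number from compound 2 to compound 4 (1.42 log units; beyond the scatter)). Exchanging the ring substituents of the benzyl group leaves the two compounds within the scatter of each other (a 1.1-fold lower number from compound 3 to compound 4 (0.05 log units; within the scatter)). Compound 2 stands only at a limit: the limit of > 10000 nM in this assay, at which 1 of the 4 values shown sits.

From the compounds shown here alone, whether an unsubstituted benzyl, a longer chain to the ring or an amine on that ring would hold these numbers remains open.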